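Aryl variation on the aromatic nitrogen: antiproliferative series notes

This account rests on a few compounds, and the source may have more. Where it says the series, first, only, none or still open, it means among the compounds named here.

Compound 1 `N#CC1=C(N)Oc2c(N)cc3nc4ccccc4nc3c2C12C(=O)N(Cc1cnnn1-c1cccc(Br)c1)c1ccccc12` — in a functional assay on HepG2 cells (Homo sapiens) for antiproliferative activity, read by MTT assay, with a stated time of 48 h (a lower number here means a stronger inhibitor, a higher number a weaker inhibitor), compound 1 gives > 50000 nM, which is a limit of the assay, not a number.
Compound 2 `N#CC1=C(N)Oc2c(N)cc3nc4ccccc4nc3c2C12C(=O)N(Cc1cnnn1-c1ccc([N+](=O)[O-])cc1)c1ccccc12` — in this assay compound 2 gives > 50000 nM, again a limit of the assay.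
Compound 3 `N#CC1=C(N)Oc2c(N)cc3nc4ccccc4nc3c2C12C(=O)N(Cc1cnnn1-c1c(F)cccc1F)c1ccccc12` — in this assay compound 3 gives > 50000 nM, likewise a limit of the assay.

Compound 3 therefore stands at a limit, and the two further values shown are limits as well, so compound 3 cannot be ranked against compound 1 or compound 2. Going by the values given here, the three steps among the measured compounds, a step that the two limits leave unreadable from compound 1 to compound 2, a step that the two limits leave unreadable from compound 1 to compound 3 and a step that the two limits leave unreadable from compound 2 to compound 3, are all left unreadable by the limits; the only evidence on them is the limit of > 50000 nM in this assay, at which 3 of the 3 values shown sit.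

Compound 4 `N#CC1=C(N)Oc2c(N)cc3nc4ccccc4nc3c2C12C(=O)N(Cc1cnnn1-c1ccc([N+](=O)[O-])cc1[N+](=O)[O-])c1ccccc12` differs from compound 3 by 2,4-dinitrophenyl in place of 2,6-difluorophenyl on an aromatic nitrogen. All three measured steps bear on this change, since each swaps the aryl group on the aromatic nitrogen, yet none has a readable size. No direction can be drawn from them; the step that the limit leaves unreadable from compound 3 to compound 4 is therefore expected to be none beyond the scatter, most likely ending at the limit again. In this assay compound 4 is estimated at 60000 nM, within 20000 nM to 200000 nM.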

Compound 4, half-maximal inhibitory concentration: 18400 nM
Compound 4: middle estimate off by 3.3-fold (0.51 log units), on the high side, outside the stated range (below it).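

Going by these compounds alone, with the aryl group on the aromatic nitrogen of the shared core, this assay now gives a first readable change at this position: 2,4-dinitrophenyl in place of 2,6-difluorophenyl gives an at least 2.7-fold lower number from compound 3 to compound 4 (0.43 log units; beyond the scatter). A nitro in place of hydrogen on an aromatic carbon of the 4-nitrophenyl group gives an at least 2.7-fold lower number from compound 2 to compound 4 (0.43 log units; beyond the scatter), so this single change is enough to bring the value off the limit, and 2,4-dinitrophenyl in place of 3-bromophenyl gives an at least 2.7-fold lower number from compound 1 to compound 4 (0.43 log units; beyond the scatter). All three sizes are bounds rather than exact differences, and the earlier aryl groups remain unranked against one another: the limit of > 50000 nM in this assay, at which 3 of the 4 values shown sit.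

Whether the gain needs both nitro groups or only the added one stays open, since each aryl group shown changes along with its whole pattern. An amine or a carboxylic acid on the same aryl ring would show whether nitro itself is needed.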